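Small chain extensions in a set of inactive compounds

The source may report more compounds than this note shows. Statements on the series, on what has been measured and on what is new or still open speak of the compounds shown alone.

Compound 1, with the structure `CCCn1nc(-c2ccc(C(=O)OCC)cc2)c2ccccc21`, was tested in a functional assay on cells (Platelet, Homo sapiens) for inhibition; on this read-out higher numbers stand for weaker inhibition and lower numbers for stronger inhibition. In this assay compound 1 gave only the limit > 10000 nM. Compound 2, `CCCCn1nc(-c2ccc(C(=O)OCC)cc2)c2ccccc21`, differs by methyl in place of hydrogen on a saturated chain carbon, three bonds along the chain from an aromatic nitrogen. Compound 2 likewise gave only the limit > 10000 nM. The step that the two limits leave unreadable from compound 1 to compound 2 is therefore of unknown size. Compound 3, `CNC(=O)c1ccc(-c2nn(Cc3ccccc3)c3ccccc23)cc1`, has a different core; the difference between the two cores is not broken down here. Compound 3 also gave only the limit > 10000 nM. Compound 4, `CCNC(=O)c1ccc(-c2nn(Cc3ccccc3)c3ccccc23)cc1`, is made from compound 3 by methyl in place of hydrogen on a saturated chain carbon bound to an amide-type nitrogen, the same kind of change as between compound 1 and compound 2, but at a different place: the carbon is bound to an amide-type nitrogen rather than three bonds along the chain from an aromatic nitrogen. Because (the limit of > 10000 nM in this assay, at which 3 of the 3 values shown sit), the step that the limit leaves unreadable from compound 3 to compound 4 is expected to remain unreadable. Compound 4 is estimated at 20000 nM.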

Compound 4, half-maximal inhibitory concentration: > 10000 nM
Compound 4: only a limit was reported (the forecaster's own chance of this, stated with the estimate: 80%); the middle value lies beyond the limit too.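

Compound 3 and compound 4 both give only a limit in this assay, so no size can be read for the step between them. The compounds shown leave open whether any of these structures inhibits, and how strongly.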